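A few compounds are considered here, and "the series" means these few. Any claim that something is new, unique, unknown or untested is made for them only; others in the source may bear on it.

Measured compounds in a functional assay on isolated protein for inhibition of Glucose-dependent insulinotropic receptor (Rattus norvegicus), read by HTRF and cAMP accumulation; a lower number here means that less compound is needed, a higher number that more compound is needed for the effect:
- compound 1 `Cc1nc(S(C)(=O)=O)ccc1Oc1ncnc(OC2CCN(C(=O)OC(C)C)CC2)c1F` gives 142 nM
- compound 2 `Cc1nc(S(C)(=O)=O)ccc1Oc1ncnc(OC2CCN(C(=O)OC(C)(C)CF)CC2)c1F` gives 138 nM
- compound 3 `Cc1nc(S(C)(=O)=O)ccc1Oc1ncnc(OC2CCN(C(=O)O[C@H](C)C(F)(F)F)CC2)c1F` gives 110 nM

Compound 1 stands highest of the three numbers. Its nearest neighbour is compound 2, with a 1.0-fold lower number from compound 1 to compound 2 (0.01 log units; within the scatter); its furthest is compound 3, with a 1.3-fold lower number from compound 1 to compound 3 (0.11 log units; within the scatter). Both steps lie within the scatter, so the three values are not separable.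

Compound 4 `Cc1nc(S(C)(=O)=O)ccc1Oc1ncnc(OC2CCN(C(=O)OC3(C(F)(F)F)CCC3)CC2)c1F` is not yet measured in this assay. Against compound 1 the change is 1-(trifluoromethyl)cyclobutyl in place of isopropyl on an oxygen next to a carbonyl group. A group of eight heavy atoms with a four-membered non-aromatic ring of carbon only and three fluorine replaces a three-carbon group on the oxygen next to the carbonyl group.

For the measured compounds named here, the steps that bear on this are those at the same oxygen: a 1.3-fold lower number from compound 1 to compound 3 (0.11 log units; within the scatter) and a 1.3-fold lower number from compound 2 to compound 3 (0.10 log units; within the scatter), both within the scatter. Larger, fluorinated groups on this oxygen have so far left the number essentially unchanged. No step beyond the scatter is therefore expected here, and compound 4 is expected at 125 nM (range 60 nM to 260 nM), meaning an expected 1.1-fold lower number from compound 1 to compound 4 (0.06 log units; within the scatter).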

Compound 4, half-maximal effective concentration: 63.3 nM
Estimate against measurement, compound 4: 2.0-fold (0.30 log units) above; the range from low to high includes it.
By their numbers in this assay, from the lowest: compounds 4, 3, 2 and 1 (each within the scatter of the next, the first and the last beyond it).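

For the compounds shown here, at the oxygen next to a carbonyl group, 1-(trifluoromethyl)cyclobutyl gives the first steps in this assay that lie beyond the scatter: a 2.2-fold lower number from compound 1 to compound 4 (0.35 log units; beyond the scatter) and a 2.2-fold lower number from compound 2 to compound 4 (0.34 log units; beyond the scatter). Going by these compounds alone, the position is therefore not as flat as the earlier compounds suggested, although the steps are modest and the one against the other trifluoromethyl-bearing group, a 1.7-fold lower number from compound 3 to compound 4 (0.24 log units; within the scatter), stays within the scatter. Nothing available accounts for this difference.

Open, going by these compounds, is how a plain cyclobutyl or a 1-methylcyclobutyl on this oxygen would compare, which would separate the contribution of the ring from that of the trifluoromethyl. Also open, on these data alone, is whether a 1-(trifluoromethyl)cyclopentyl group or an amine-bearing ring at the same place would move the number further.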